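A few compounds are considered here, and "the series" means these few. Any claim that something is new, unique, unknown or untested is made for them only; others in the source may bear on it.

Values in a functional assay on Hs68 cells (Homo sapiens) for cytotoxicity (on this read-out higher numbers stand for lower toxicity in this test and lower numbers for higher toxicity in this test), so far:

- compound 1 `CC(C)Oc1ccccc1CNC(=O)c1ccc2cncc(Br)c2n1` gives 9 ug/mL in this test
- compound 2 `CC(C)Oc1ccccc1CNC(=O)c1ccc2cncc(Cl)c2n1` gives 6 ug/mL in this test
- compound 3 `CC(C)Oc1ccccc1CNC(=O)c1ccc2cnccc2n1` gives 2.5 ug/mL in this test

Compound 3 has the lowest number of the three, so it is the most toxic to these cells in this assay, and both other compounds lie beyond the usual scatter from it. The next compound to test is compound 4 `CC(C)(C)Oc1ccccc1CNC(=O)c1ccc2cnccc2n1`, which has not been measured yet. The change is methyl in place of hydrogen on a saturated chain carbon bound to an oxygen on an aromatic ring and two saturated chain carbons, which turns isopropoxy into tert-butoxy.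

For the measured compounds named here, no measured step touches this part of the molecule. All three concern the bromo or chloro on the shared core. Replacing those groups with hydrogen gave a 3.6-fold lower number from compound 1 to compound 3 (0.56 log units; beyond the scatter) and a 2.4-fold lower number from compound 2 to compound 3 (0.38 log units; beyond the scatter), while the swap between the two gave a 1.5-fold lower number from compound 1 to compound 2 (0.18 log units; within the scatter) in the same test. These steps show how far a single small change has moved the number in this series, but they give no direction for the new change. The expected result is therefore a 1.2-fold higher number from compound 3 to compound 4 (0.08 log units; within the scatter), with no firm direction and probably nothing beyond the scatter. Compound 4 is estimated at 3 ug/mL with an expected range from 1.2 ug/mL to 7 ug/mL in this test.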

Compound 4, half-maximal cytotoxic concentration: 4.4 ug/mL
Estimate against measurement, compound 4: 1.5-fold (0.17 log units) below; low and high end bracket the measured number.
By their numbers in this assay, from the lowest: compounds 3, 4, 2 and 1 (each within the scatter of the next, the first and the last beyond it).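

In this assay, for the compounds shown here, this is the first step at the isopropoxy group, and turning it into tert-butoxy gives a 1.8-fold higher number from compound 3 to compound 4 (0.25 log units; within the scatter), so the two numbers cannot be told apart. The earlier steps shown here beyond the scatter all lie on the shared core, such as a 3.6-fold lower number from compound 1 to compound 3 (0.56 log units; beyond the scatter), whereas adding a methyl on this saturated chain carbon stays within the scatter, at least for this single pair and with hydrogen on that aromatic carbon of the core. No measurement is available that could explain this result.

The compounds shown leave open whether a different group on this oxygen, such as a longer chain like n-butyl, a cyclopropyl ring or a plain hydrogen giving a free hydroxyl, would move the number beyond the scatter. Going by these compounds alone, they also leave open whether tert-butoxy would sit within the scatter of isopropoxy when bromo or chloro is present on the core, since the only pair at this position carries neither.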